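A few compounds are considered here, and "the series" means these few. Any claim that something is new, unique, unknown or untested is made for them only; others in the source may bear on it.

Measured compounds:
- compound 1, `O=C(CCCCCCc1ccccn1)c1ncc(-c2ccccn2)o1`: 120 nM
- compound 2, `O=C(O)c1ccc(CCCCCCC(=O)c2ncc(-c3ccccn3)o2)cc1`: > 600 nM

In an assay for inhibition of Fatty-acid amide hydrolase 1 (Rattus norvegicus) (a lower number here means a stronger inhibitor, a higher number a weaker inhibitor), compound 1 gives 120 nM. For compound 2 the assay returns only a limit, > 600 nM, so its true potency is not pinned to a number. Compound 2 therefore stands at the limit of > 600 nM in this assay, at which 1 of the 2 values shown sits, and is the weaker of the two shown. Going by the values given here, the single measured step, an at least 5.0-fold higher number from compound 1 to compound 2 (0.69 log units; beyond the scatter), is the only comparison available.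

Compound 3, `CS(=O)(=O)c1ccc(CCCCCCC(=O)c2ncc(-c3ccccn3)o2)cc1`, keeps the whole skeleton of compound 2 and differs only at the end of the chain: methylsulfonyl in place of carboxy on an aromatic carbon. Among the compounds with values here, no measured step covers a swap of this kind; the one known step changed a different group, so it says little about what methylsulfonyl does in place of carboxy. With compound 2 known only as a limit, the starting point of the step is itself uncertain. The estimate for compound 3 in this assay is therefore 900 nM, within 200 nM to 4000 nM, which means an expected step that the limit leaves unreadable from compound 2 to compound 3 and a real chance that compound 3 again falls at the limit.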

Compound 3, inhibition constant: 19 nM
Beside the measured number, compound 3's estimate is 47-fold (1.68 log units) above it, outside the stated range (below it).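

In this assay, the group on this aromatic carbon turns out to matter a great deal: methylsulfonyl in place of carboxy gives an at least 31-fold lower number from compound 2 to compound 3 (1.49 log units; beyond the scatter). The earlier step alone could have been read as a penalty for having a carbon-only aromatic ring at the end of the chain, yet that ring is also present in compound 3, which gives 19 nM, while compound 1 gives 120 nM. As far as these compounds go, the true size of the new step remains open-ended, since compound 2 is known only as a limit: the limit of > 600 nM in this assay, at which 1 of the 3 values shown sits.

With only carboxy and methylsulfonyl shown on this carbon, it remains unclear how much of the gain comes from adding methylsulfonyl and how much from losing carboxy. A hydrogen, a nitrile or a primary sulfonamide on the same carbon would help separate these two readings, and a shorter or longer chain would test whether the result holds beyond this chain.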